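The compounds below may be only part of what the source reports. "The series", "measured", "known", "first", "only" and "open" are said of these compounds alone.

Working notes on the series. For the measured compounds named here, in a physicochemical assay for solubility, at pH 6.8 (a lower number here means a less soluble compound, a higher number a more soluble compound), compound 2 `C[C@H](NC(=O)C1CCOCC1)c1ccc(NC(=O)[C@H]2C[C@@H]2c2cccnc2)cc1` gives 90000 nM, the only true number so far. Compound 1 `O=C(NCc1cccnc1)Nc1ccc(CNC(=O)c2ccc(CN3CCNCC3)cc2)cc1` reads > 1000000 nM, which is a limit of this assay and not a number. Compound 3 `C[C@H](NC(=O)c1ccccc1)c1ccc(NC(=O)[C@H]2C[C@@H]2c2cccnc2)cc1` reads < 4000 nM, which is also a limit.

The next compound to read is compound 4 `C[C@H](NC(=O)c1ccc(F)cc1)c1ccc(NC(=O)[C@H]2C[C@@H]2c2cccnc2)cc1`. Its change from compound 2 is 4-fluorophenyl in place of oxan-4-yl on a carbonyl carbon. Going by the values given here, the one measured step that bears on this is an at least 22-fold lower number from compound 2 to compound 3 (1.35 log units; beyond the scatter), with phenyl in place of the same oxan-4-yl. On these data alone, that step is large and beyond the scatter, and it ends on a limit, so its full size stays open. The 4-fluorophenyl likewise brings one six-membered aromatic ring of carbon only. A large step to a lower number in this assay is therefore expected, of about the same size. The estimated step is a 30-fold lower number from compound 2 to compound 4 (1.48 log units; beyond the scatter). For compound 4 the estimate is 3000 nM, with an expected range of 1000 nM to 8000 nM, and a report only as a limit is quite possible.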

Compound 4, solubility: 6000 nM
Compound 4: the middle estimate sits 2.0-fold (0.30 log units) below what was measured, and the stated range covers the measured number.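

In this assay the change from oxan-4-yl to an aromatic ring of carbon only, on this carbonyl carbon, now has a size that ends on a true number: a 15-fold lower number from compound 2 to compound 4 (1.18 log units; beyond the scatter), where the earlier phenyl step gave only a floor. Fluoro in place of hydrogen on an aromatic carbon gives an at least 1.5-fold higher number from compound 3 to compound 4 (0.17 log units; that floor lies within the scatter), so this pair shows no change that can be read beyond the scatter. Compound 3 remains a limit and not a number: the limit of < 4000 nM in this assay, at which 1 of the 4 values shown sits.

On these data alone, the true size of the fluoro step stays open while compound 3 stands at that limit. Also open, as far as these compounds go, is how an amine or a carboxylic acid carried on the phenyl, or a longer chain in its place, would read in this assay against compound 2 at 90000 nM.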